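Halogen exchange on the shared core in cell inhibition

A few compounds are considered here, and "the series" means these few. Any claim that something is new, unique, unknown or untested is made for them only; others in the source may bear on it.

Compound 1 `CC(=O)OCCOCn1cnc2c(Cl)ncnc21` gives 475 ug/mL in a functional assay on L1210 cells (Mus musculus) for inhibition; on this read-out higher numbers stand for weaker inhibition and lower numbers for stronger inhibition. Compound 2 `Nc1nc2c(nc(Cl)n2COCCO)c(=O)[nH]1` has a different core, and in this assay compound 2 reaches only a limit, > 1000 ug/mL, not a number. Compound 3 `Nc1nc2c(nc(Br)n2COCCO)c(=O)[nH]1` likewise sits at a limit in this assay, > 500 ug/mL, with no number behind it. Among the measured compounds shown here, the single measured step, a step that the two limits leave unreadable from compound 2 to compound 3, cannot be sized because both ends are limits the limit of > 1000 ug/mL in this assay, at which 1 of the 3 values shown sits, and (the limit of > 500 ug/mL in this assay, at which 1 of the 3 values shown sits). Compound 4 `Nc1nc2c(nc(I)n2COCCO)c(=O)[nH]1` carries iodo in place of bromo on an aromatic carbon. For the measured compounds named here, no measured step reads an exchange of one halogen for another, so no shift beyond the scatter is expected. Compound 4 is estimated at 600 ug/mL, in the range 250 ug/mL to 2000 ug/mL. The expected step that the limit leaves unreadable from compound 3 to compound 4 is flat, and a limit rather than a number is expected.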

Compound 4, concentration for 50% inhibition: > 1000 ug/mL
Compound 4: only a limit was reported; the forecaster's own chance of this, stated with the estimate: 70%; middle value at least 1.6-fold (0.22 log units) from the limit.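

Among the compounds shown here, compound 2, compound 3 and compound 4 all stand at limits in this assay, and no step among them can be read. The compounds shown leave open whether exchanging one halogen for another changes inhibition on the shared core.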